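The source may hold more compounds than are shown below. What is called first, only, known or untested is meant among the compounds shown, and "the series" means these compounds.

Three compounds built on one shared core have been examined in an assay on isolated protein for inhibition of kynurenine 3-monooxygenase (Rattus norvegicus); on this read-out lower numbers stand for stronger inhibition and higher numbers for weaker inhibition. Compound 1 `Cc1ccc(-c2csc(NS(=O)(=O)c3ccc(C)cc3)n2)cc1` gives 76 nM in this assay. Compound 3 `Cc1ccc(S(=O)(=O)Nc2nc(-c3ccc(Cl)c(Cl)c3)cs2)cc1` gives 56 nM, and the single-point step from compound 1 to compound 3 reads a 1.4-fold lower number from compound 1 to compound 3 (0.13 log units; within the scatter), a change confined to the aryl group at the far end of the molecule from the ring that carries the methyl of interest here. Compound 2 `Cc1ccc(S(=O)(=O)Nc2nc(-c3cccc([N+](=O)[O-])c3)cs2)cc1` gives 48 nM; this is the lowest of the three numbers, yet it sits within the scatter of both compound 3 and compound 1, so the three cannot be ranked against one another.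

The unmeasured compound 4 `O=[N+]([O-])c1cccc(-c2csc(NS(=O)(=O)c3ccccc3)n2)c1` departs from compound 2 by hydrogen in place of methyl on an aromatic carbon. For the measured compounds named here, no measured pair touches this ring: the one step on record, from compound 1 to compound 3, alters the opposite aryl group and therefore bears only indirectly on the question, and it was itself within the scatter. With nothing in the data pointing to a shift in either direction, the expectation for the step from compound 2 to compound 4 is none beyond the scatter, estimated at a 1.5-fold higher number from compound 2 to compound 4 (0.16 log units; within the scatter). Compound 4 is accordingly expected to give about 70 nM in this assay, estimated to lie between 25 nM and 200 nM.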

Compound 4, half-maximal inhibitory concentration: 200 nM
The estimate for compound 4 lay 2.9-fold (0.46 log units) below the measured number, and the stated range covers the measured number.
By their numbers in this assay, from the lowest: compounds 2, 3 and 1 (each within the scatter of the next); then compound 4.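

For the compounds shown here, removing the methyl of the 4-methylphenyl group gives a 4.2-fold higher number from compound 2 to compound 4 (0.62 log units; beyond the scatter) in this assay, and this is the only step in the set that lies beyond the scatter. The earlier step, a 1.4-fold lower number from compound 1 to compound 3 (0.13 log units; within the scatter), changed the other aryl group and left the number within the scatter, whereas this result shows that the read-out can respond to the loss of a single carbon atom at this position, at least with the rest of compound 2 held fixed. No measured property of these compounds bears on the reason for this step.

As far as these compounds go, it remains open whether the methyl itself matters at this carbon or whether another group would serve as well; an ethyl, a methoxy, a chlorine or an amine in the same place would help to separate those two readings. Going by these compounds alone, it is also open whether the step carries over when the other aryl group is the one found in compound 1 or compound 3, as this change is read here only on the background of compound 2.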